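This account rests on a few compounds, and the source may have more. Where it says the series, first, only, none or still open, it means among the compounds named here.

Measured compounds in a functional assay on MDA-MB-435 cells (Homo sapiens) for cytotoxicity, read by MTT assay, with a stated time of 72 h; a higher number here means a weaker inhibitor, a lower number a stronger inhibitor:
- compound 1 `CC(C)(C)OC(=O)N1CCN(c2c(C(=O)NCc3ccc(F)cc3)nc(Br)c3cccnc23)CC1`: 10000 nM
- compound 2 `CN(C)CCCNc1c(C(=O)NCc2ccc(F)cc2)nc(Br)c2cccnc12`: 7000 nM
- compound 3 `CS(=O)(=O)NCCCN(c1nc(C(=O)NCc2ccc(F)cc2)c(O)c2ncccc12)S(C)(=O)=O`: > 20000 nM, a limit of the assay, not a number

Compound 2 gives one of two plain numbers here, and its value and that of compound 1 sit within the scatter of each other, so no order between them can be read. Compound 3 reports only a limit (the limit of > 20000 nM in this assay, at which 1 of the 3 values shown sits). Compound 4 `COC(=O)CNc1c(C(=O)NCc2ccc(F)cc2)nc(Br)c2cccnc12` is not yet measured in this assay; it differs from compound 2 by the change (methoxycarbonyl in place of 2-(dimethylamino)ethyl on a saturated chain carbon bound to a nitrogen on an aromatic ring). Within the data shown here, no measured pair shows this change or anything close to it, so no step beyond the scatter is expected in either direction; compound 2 and compound 4 are expected to give values of the same order, with a step of a 1.4-fold higher number from compound 2 to compound 4 (0.15 log units; within the scatter) for compound 4 resting on compound 2 at 7000 nM. Compound 4 is accordingly estimated at 10000 nM, between 4000 nM and 25000 nM.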

Compound 4, half-maximal inhibitory concentration: 10000 nM
For compound 4 middle estimate and measured number coincide at the digits printed; measured number inside the range.
By their numbers in this assay, from the lowest: compounds 2, 1 and 4 (each within the scatter of the next). At a limit, above all of these: compound 3.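

At the saturated chain carbon bound to a nitrogen on an aromatic ring, methoxycarbonyl in place of 2-(dimethylamino)ethyl gives, in this assay, a 1.4-fold higher number from compound 2 to compound 4 (0.15 log units; within the scatter). Among these compounds, this is the first comparison that differs in one place, and it does not separate the two chain ends. No measured property bears on this step.

Going by these compounds, whether a carboxylic acid, a primary amide or a longer chain at this place would give a step beyond the scatter remains open. So does whether a cyclic amine such as morpholine would.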